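This account rests on a few compounds, and the source may have more. Where it says the series, first, only, none or still open, it means among the compounds named here.

Compound 2 `O=C1c2ccccc2C(=O)N1CCOC(=S)N(C(=O)c1c(F)cccc1F)c1ccc(Cl)cc1` gives 39000 nM in an ADME assay on MT4 cells (Homo sapiens) for cytotoxicity, read by MTT assay (on this read-out lower numbers stand for higher toxicity in this test and higher numbers for lower toxicity in this test), the highest of the two numbers gathered so far; compound 1 `Cc1ccccc1C(=O)N(C(=S)OCCN1C(=O)c2ccccc2C1=O)c1ccc(Cl)cc1` gives 21000 nM, and the step of a 1.9-fold higher number from compound 1 to compound 2 (0.27 log units; within the scatter) lies within the scatter, so the two stand at the same level. Compound 3 `O=C1c2ccccc2C(=O)N1CCOC(=S)N(C(=O)c1cc([N+](=O)[O-])ccc1Cl)c1ccc(Cl)cc1` is not yet measured. The change from compound 2 to compound 3 is 2-chloro-5-nitrophenyl in place of 2,6-difluorophenyl on a carbonyl carbon. Within the data shown here, the only measured step that bears on this is the earlier aryl swap on the same carbonyl carbon, a 1.9-fold higher number from compound 1 to compound 2 (0.27 log units; within the scatter), which stayed within the scatter; a second aryl swap at the same place is therefore expected to move the number by no more than the scatter, in no set direction. Compound 3 is expected near 30000 nM, with a range of 12000 nM to 80000 nM, meaning an expected step of a 1.3-fold lower number from compound 2 to compound 3 (0.11 log units; within the scatter).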

Compound 3, half-maximal cytotoxic concentration: 45000 nM
Beside the measured number, compound 3's estimate is 1.5-fold (0.18 log units) below it; the measured number falls inside the stated range.
By their numbers in this assay, from the lowest: compounds 1, 2 and 3 (each within the scatter of the next, the first and the last beyond it).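

In this assay, a further aryl swap on the carbonyl carbon whose other neighbour is the amide-type nitrogen again stays within the scatter (a 1.2-fold higher number from compound 2 to compound 3 (0.06 log units; within the scatter)), although 2-chloro-5-nitrophenyl brings 2 hydrogen-bond acceptors where 2,6-difluorophenyl has 0. Among these compounds, the first step beyond the scatter appears only between the two ends of the set (a 2.1-fold higher number from compound 1 to compound 3 (0.33 log units; beyond the scatter)), and it is modest, while each neighbouring pair stays within the scatter. Nothing measured here offers a reason for either step.

On these data alone, whether a simple alkyl chain or an aryl ring bearing an amine or a carboxylic acid at this carbonyl carbon would shift the number remains open. Also open, as far as these compounds go, is whether changes elsewhere on the shared core would move it further than these aryl swaps do.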